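This account rests on a few compounds, and the source may have more. Where it says the series, first, only, none or still open, it means among the compounds named here.

Measured compounds:
- compound 1 `[O-][S+](CCNC1CCN(CC(O)Cc2ccccc2)CC1)C(c1ccc(F)cc1)c1ccc(F)cc1`: in an assay on membranes from Cortex for displacement of a labelled ligand from Sigma non-opioid intracellular receptor 1 (Cavia porcellus), read by scintillation counting, with a stated time of 120 min (a lower number here means a stronger inhibitor, a higher number a weaker inhibitor), compound 1 gives 351 nM
- compound 2 `O=C(c1ccccc1)N1CCC(NCC[S+]([O-])C(c2ccc(F)cc2)c2ccc(F)cc2)CC1`: in this assay compound 2 gives 585 nM
- compound 3 `CC(C)(C)CN1CCC(NCC[S+]([O-])C(c2ccc(F)cc2)c2ccc(F)cc2)CC1`: in this assay compound 3 gives 542 nM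

Compound 3 stands second highest of the three numbers. Its nearest neighbour is compound 2, separated by a 1.1-fold lower number from compound 2 to compound 3 (0.03 log units; within the scatter); the furthest is compound 1, separated by a 1.5-fold higher number from compound 1 to compound 3 (0.19 log units; within the scatter). Both gaps lie within the scatter, so the three compounds cannot be ordered on these numbers.

Compound 4 `O=C(c1ccccc1F)N1CCC(NCC[S+]([O-])C(c2ccc(F)cc2)c2ccc(F)cc2)CC1` is not yet measured. It differs from compound 3 in one place: (2-fluorophenyl)carbonyl in place of neopentyl on an amine nitrogen in a ring.

Among the measured compounds shown here, the step that bears on this change is the one between compound 2 and compound 3, which swapped benzoyl for neopentyl on the same ring nitrogen and gave a 1.1-fold lower number from compound 2 to compound 3 (0.03 log units; within the scatter), within the scatter. For the measured compounds named here, the change to compound 4 is the reverse of that swap, with a fluorine added on the phenyl of the carbonyl; no measured pair shows what that fluorine does. The other step at this nitrogen, a 1.7-fold higher number from compound 1 to compound 2 (0.22 log units; within the scatter), also stayed within the scatter. On these grounds no step beyond the scatter is expected in this assay, and compound 4 is estimated to give a 1.0-fold higher number from compound 3 to compound 4 (0.01 log units; within the scatter) relative to compound 3.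

Compound 4 is therefore estimated at 560 nM, with an expected range of 300 nM to 1100 nM.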

Compound 4, inhibition constant: 1310 nM
Compound 4: middle estimate off by 2.3-fold (0.37 log units), on the low side; the measured number lies above the stated range.
By their numbers in this assay, from the lowest: compounds 1, 3 and 2 (each within the scatter of the next); then compound 4.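

In this assay, fluoro in place of hydrogen on an aromatic carbon gives a 2.2-fold higher number from compound 2 to compound 4 (0.35 log units; beyond the scatter), so a single substitution on the phenyl of the carbonyl group produces a step beyond the scatter at a position where the earlier swaps had produced none. Set on the amine nitrogen in a ring, (2-fluorophenyl)carbonyl also gives a 2.4-fold higher number from compound 3 to compound 4 (0.38 log units; beyond the scatter) against neopentyl and a 3.7-fold higher number from compound 1 to compound 4 (0.57 log units; beyond the scatter) against 2-hydroxy-3-phenylpropyl, whereas benzoyl stayed within the scatter of both groups, with a 1.7-fold higher number from compound 1 to compound 2 (0.22 log units; within the scatter) and a 1.1-fold lower number from compound 2 to compound 3 (0.03 log units; within the scatter). This nitrogen is therefore not indifferent to the group it carries, and in this series the difference appears only once the fluorine is present, although no measurement at hand explains the shift.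

From the compounds shown here alone, whether a chloro, methyl or methoxy group in place of this fluorine would give a step of similar size remains open. Also open, going by these compounds, is whether fluoro on the phenyl of the 2-hydroxy-3-phenylpropyl group would raise the number as it does on the benzoyl group.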